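The compounds below may be only part of what the source reports. "The series", "measured", "known", "first", "only" and "open" are said of these compounds alone.

Of the compounds shown here, three have so far been measured in a functional assay on HCT-116 cells (Homo sapiens) for inhibition, read by colorimetric assay, with a stated time of 3 days; a lower number here means a stronger inhibitor, a higher number a weaker inhibitor. Compound 1 `O=C(CCCCCCNC(=O)C(O)(O)C(F)(F)F)Nc1nc(-c2ccccc2)c(-c2ccccc2)s1` gives 29900 nM. Compound 2 `O=C(CCCCCCNC(=O)C(O)(O)C(F)(F)F)Nc1cccc(Br)c1` gives 3060 nM, the lowest of the two numbers, and the gap between compound 2 and compound 1 lies beyond the usual scatter. Compound 3 `NC(=O)C(=O)NCCCCCC(=O)Nc1ccccc1` gives no number, only a limit of the assay, > 100000 nM. For compound 3 that reading is the limit of > 100000 nM in this assay, at which 1 of the 3 values shown sits.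

Compound 4 `COc1cccc(NC(=O)CCCCCCNC(=O)C(O)(O)C(F)(F)F)c1` has not yet been measured. It differs from compound 2 in one place: methoxy in place of bromo on an aromatic carbon. No measured pair among these compounds shows the effect of this exchange, so the expectation rests on compound 2 alone, together with the fact that the change is a small one on the outer ring. The expected step is a 1.6-fold higher number from compound 2 to compound 4 (0.21 log units; within the scatter), that is, a slight weakening that may not reach beyond the scatter. Compound 4 is therefore estimated to give 5000 nM in this assay, with a likely range from 1500 nM to 16000 nM.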

Compound 4, half-maximal inhibitory concentration: 6110 nM
Compound 4: middle estimate off by 1.2-fold (0.09 log units), on the low side; low and high end bracket the measured number.
By their numbers in this assay, from the lowest: compounds 2 and 4 (each within the scatter of the next); then compound 1. At a limit, above all of these: compound 3.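

Within the data shown here, compound 4 supplies the first measured exchange at this place on the outer ring: in this assay there is a 2.0-fold higher number from compound 2 to compound 4 (0.30 log units; within the scatter) for methoxy in place of bromo on an aromatic carbon. Going from 3-bromophenyl to 3-methoxyphenyl swaps one heavy atom for two and adds a hydrogen-bond acceptor, yet the two readings cannot be told apart, so this one exchange at this place leaves the number unmoved within the scatter. Nothing measured among these compounds offers a reason for that result.

As far as these compounds go, whether the same holds for very different groups stays open, for instance an amine or a carboxylic acid at this place on the ring. From the compounds shown here alone, it is also open how this exchange would read with a longer chain or on another ring carbon.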